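This account rests on a few compounds, and the source may have more. Where it says the series, first, only, none or still open, it means among the compounds named here.

Of the compounds shown here, three built on one shared core have been tested in an assay on CHO-K1 cells for displacement of a labelled ligand from Orexin receptor type 2 (Homo sapiens), read by radioligand binding; on this read-out higher numbers stand for weaker inhibition and lower numbers for stronger inhibition. Compound 1 `C#Cc1ccnc(O[C@@H]2CC[C@@H](C)N(C(=O)c3ccccc3-n3nccn3)C2)c1` gives 0.6 nM, compound 2 `COC(=O)c1ccnc(O[C@@H]2CC[C@@H](C)N(C(=O)c3ccccc3-n3nccn3)C2)c1` gives 3.9 nM, and compound 3 `C[C@@H]1CC[C@@H](Oc2cc(Br)ccn2)CN1C(=O)c1ccccc1-n1nccn1` gives 1.8 nM. Among these three numbers compound 3 stands second highest, below compound 2 and above compound 1.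

Compound 4 `C[C@@H]1CC[C@@H](Oc2cc(-c3ccccc3)ccn2)CN1C(=O)c1ccccc1-n1nccn1` has not yet been measured. It differs from compound 3 by phenyl in place of bromo on an aromatic carbon. The measured steps that bear on this change are those in which the group on that same aromatic carbon was exchanged: a 3.0-fold higher number from compound 1 to compound 3 (0.48 log units; beyond the scatter) and a 2.2-fold lower number from compound 2 to compound 3 (0.34 log units; beyond the scatter), with a 6.5-fold higher number from compound 1 to compound 2 (0.81 log units; beyond the scatter) as the third comparison among the three. All were modest, so exchanging the group at this position has so far shifted the number only within a narrow band, though none of the groups tried was a ring, and phenyl lies outside what has been measured.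

On that basis the estimated step for compound 4 is a 1.7-fold higher number from compound 3 to compound 4 (0.22 log units; within the scatter), a small rise rather than a move beyond the band seen so far. The value expected for compound 4 in this assay is 3 nM, with a range from 0.8 nM to 12 nM.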

Compound 4, inhibition constant: 3.8 nM
For compound 4 the middle estimate is 1.3-fold (0.10 log units) below the measured one; measured number inside the range.
By their numbers in this assay, from the lowest: compound 1; then compound 3; then compounds 4 and 2 (each within the scatter of the next).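

A ring can sit on this aromatic carbon, opposite the ring nitrogen, without the number leaving the narrow band seen so far: in this assay, the phenyl group, with its six heavy atoms against the single atom of bromo, gives a 2.1-fold higher number from compound 3 to compound 4 (0.32 log units; beyond the scatter) as a step of only modest size. Replacing methoxycarbonyl, a group without a ring, with phenyl gives a 1.0-fold lower number from compound 2 to compound 4 (0.01 log units; within the scatter) and so does not separate the two groups, whereas ethynyl keeps the lowest number of the series, with a 6.3-fold higher number from compound 1 to compound 4 (0.80 log units; beyond the scatter) as the step away from it. Nothing available explains this order among the groups.

Going by these compounds, it remains open whether an amine, a carboxylic acid or a longer chain on this same carbon would stay within the band or move the number well outside it. All four compounds also share the rest of their structure, so whether this order of groups would hold with a change elsewhere on the shared core is equally unsettled.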